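Compound 4: trifluoromethyl in place of tert-butyl

A few compounds are considered here, and "the series" means these few. Any claim that something is new, unique, unknown or untested is made for them only; others in the source may bear on it.

The series shares one core, seen in compound 1 `COc1cc(-c2ccnc3cc(-c4ccc(C(C)(C)C)cc4)nn23)cc(OC)c1OC`. In a functional assay on HCT-116 cells (Homo sapiens) for inhibition, read by CCK-8 assay, with a stated time of 48 h (on this read-out higher numbers stand for weaker inhibition and lower numbers for stronger inhibition), compound 1 gives > 10000 nM, which is a limit of the assay and not a number. Compound 2 `CCOC(=O)c1ccc(-c2cc3nccc(-c4cc(OC)c(OC)c(OC)c4)n3n2)cc1` carries an ethoxycarbonyl where compound 1 carries tert-butyl. In this assay compound 2 gives > 10000 nM, again a limit. The step that the two limits leave unreadable from compound 1 to compound 2. For the measured compounds named here, compound 3 `COc1cc(-c2ccnc3cc(-c4cccc(C)c4)nn23)cc(OC)c1OC`, with 3-methylphenyl in place of 4-(tert-butyl)phenyl, gives 6150 nM in this assay, the only number in the set. The step of an at least 1.6-fold lower number from compound 1 to compound 3 (0.21 log units; that floor lies within the scatter). Compound 1 thus stands at the limit of > 10000 nM in this assay, at which 2 of the 3 values shown sit.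

Compound 4 `COc1cc(-c2ccnc3cc(-c4ccc(C(F)(F)F)cc4)nn23)cc(OC)c1OC` differs from compound 1 in one place: trifluoromethyl in place of tert-butyl on an aromatic carbon. Of the measured steps only the two from compound 1 bear on it; one is unreadable and the other has a floor that lies within the scatter. A change at the same place, giving compound 2, stayed at the limit. Compound 4 is therefore expected to remain near the limit, with an expected step of a number no higher from compound 1 to compound 4 (the limit leaves the size open) that need not exceed the scatter. The estimate for compound 4 in this assay is 10000 nM, within 4000 nM to 30000 nM.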

Compound 4, half-maximal inhibitory concentration: 1860 nM
The estimate for compound 4 lay 5.4-fold (0.73 log units) above the measured number; measured number outside the range, below it.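

In this assay, the aromatic carbon that carries tert-butyl in compound 1 proves open to gain: trifluoromethyl there gives an at least 5.3-fold lower number from compound 1 to compound 4 (0.73 log units; beyond the scatter), the first step from compound 1 that clears the scatter. The group at this carbon decides the outcome, since exchanging ethoxycarbonyl for trifluoromethyl gives an at least 5.3-fold lower number from compound 2 to compound 4 (0.73 log units; beyond the scatter), and both of these steps start from a limit of the assay, so their sizes are floors: the limit of > 10000 nM in this assay, at which 2 of the 4 values shown sit. The 4-(trifluoromethyl)phenyl also outdoes the 3-methylphenyl, with a 3.3-fold lower number from compound 3 to compound 4 (0.52 log units; beyond the scatter), which leaves compound 4 with the lowest number in the set.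

The compounds shown do not tell which feature of trifluoromethyl accounts for this. On these data alone, whether a single fluorine atom, a nitrile or a methoxy group at the same carbon would match it remains open.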